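The source may hold more compounds than are shown below. What is called first, only, known or untested is meant among the compounds shown, and "the series" means these compounds.

Measured compounds in an ADME assay on MT4 cells (Homo sapiens) for cytotoxicity, read by MTT assay, with a stated time of 5 days; on this read-out higher numbers stand for lower toxicity in this test and lower numbers for higher toxicity in this test:

Compound 1, `Cc1cc(C)c(Oc2cc(Nc3ccc(C#N)cc3)ncc2C(=O)NCc2cn(Cc3cccc(Cl)c3)nn2)c(C)c1`, 187000 nM
Compound 2, `Cc1cc(C)c(Oc2cc(Nc3ccc(C#N)cc3)ncc2C(=O)NCc2cn(CCC#N)nn2)c(C)c1`, 40200 nM
Compound 3, `Cc1cc(C)c(Oc2cc(Nc3ccc(C#N)cc3)ncc2C(=O)NCc2cn(Cc3cccc(C#N)c3)nn2)c(C)c1`, >= 129000 nM

The value given for compound 3 is a limit of this assay, not a number, so compound 3 stands only at or beyond the limit of >= 129000 nM in this assay, at which 1 of the 3 values shown sits, among the three. Compound 4, `Cc1cc(C)c(Oc2cc(Nc3ccc(C#N)cc3)ncc2C(=O)NCc2cn(CC(=O)N3CCCC3)nn2)c(C)c1`, has not yet been measured. It differs from compound 3 in one place: (pyrrolidin-1-yl)carbonyl in place of 3-cyanophenyl on a saturated chain carbon bound to an aromatic nitrogen.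

Going by the values given here, two measured steps bear on this change, as both swap an aromatic ring on the saturated chain carbon bound to the aromatic nitrogen for a small non-aromatic chain, or the reverse. The step of a 4.7-fold lower number from compound 1 to compound 2 (0.67 log units; beyond the scatter) lowered the number, and the step of an at least 3.2-fold higher number from compound 2 to compound 3 (0.50 log units; beyond the scatter) raised it. Compound 4 likewise removes the aromatic ring from that carbon, so a lowering of the number in this assay is expected, of about the size seen for those two steps, though the limit on compound 3 leaves the starting point uncertain. The expected step is an at least 2.1-fold lower number from compound 3 to compound 4 (0.33 log units; beyond the scatter). Compound 4 is therefore estimated at 60000 nM in this assay, within a range from 25000 nM to 160000 nM.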

Compound 4, half-maximal cytotoxic concentration: 58100 nM
The estimate for compound 4 lay 1.0-fold (0.01 log units) above the measured number; the range from low to high includes it.
By their numbers in this assay, from the lowest: compounds 2 and 4 (each within the scatter of the next); then compound 1.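

In this assay, the (pyrrolidin-1-yl)carbonyl group on a saturated chain carbon bound to an aromatic nitrogen gives an at least 2.2-fold lower number from compound 3 to compound 4 (0.34 log units; beyond the scatter) and a 3.2-fold lower number from compound 1 to compound 4 (0.51 log units; beyond the scatter), so a third non-aromatic comparison now joins the earlier one: both compounds carrying a benzyl group with an aromatic ring there stand above both compounds without one, and no compound shown goes against this. The a 1.4-fold higher number from compound 2 to compound 4 (0.16 log units; within the scatter) shows that, in this read-out, the (pyrrolidin-1-yl)carbonyl and cyanomethyl groups cannot be told apart, although only the first of them brings a ring of its own, a five-membered non-aromatic one. Compound 3 still stands at a limit of the assay and not at a number, so its step gives only a minimum size: the limit of >= 129000 nM in this assay, at which 1 of the 4 values shown sits.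

From the compounds shown here alone, with four compounds, it remains open whether this order belongs to the aromatic ring itself or to the chloro and cyano groups on it, and an unsubstituted benzyl group would bear on that question. Going by these compounds, how a carboxylic acid, an amine or a six-membered piperidine amide on the same chain carbon would stand in this assay also remains open.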